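Removing a Methoxy Group From Two Related Compounds

The source may hold more compounds than are shown below. What is called first, only, known or untested is meant among the compounds shown, and "the series" means these compounds.

Measurements in an ADME assay for metabolic stability, at pH 3.0 (on this read-out lower numbers stand for a shorter-lived compound and higher numbers for a longer-lived compound), exist for compound 1, compound 2 and compound 3. Compound 1 `COc1ccc2c(c1)COP(=O)(OCC1CCC(n3cnc4c(N)ncnc43)O1)O2` gives 12.2 h, and compound 3 `Nc1ncnc2c1ncn2C1CCC(COP2(=O)OCc3ccccc3O2)O1` gives 12.9 h. Between them lies a single change, (hydrogen in place of methoxy on an aromatic carbon), which produced a 1.1-fold higher number from compound 1 to compound 3 (0.02 log units; within the scatter). Compound 2 `COc1ccc2c(c1)COP(=O)(OC[C@@H]1C=C[C@H](n3cnc4c(N)ncnc43)O1)O2` gives 0.14 h in this assay, the lowest of the three values; the difference between the core of compound 2 and the core of compound 1 is not broken down here.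

Compound 4 `Nc1ncnc2c1ncn2[C@H]1C=C[C@@H](COP2(=O)OCc3ccccc3O2)O1` has not yet been measured. It differs from compound 2 by hydrogen in place of methoxy on an aromatic carbon, the same change, at the same kind of place, that separates compound 1 from compound 3. Because the earlier step was a 1.1-fold higher number from compound 1 to compound 3 (0.02 log units; within the scatter), this change alone is expected to leave the half-life of compound 4 close to that of compound 2, and the step is estimated as a 1.1-fold higher number from compound 2 to compound 4 (0.03 log units; within the scatter). That expectation rests on one measured pair whose core is not the core of compound 2, so it is held loosely. Compound 4 is therefore expected to give about 0.15 h, within a range of 0.07 h to 0.32 h.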

Compound 4, half-life: 0.14 h
For compound 4 the middle estimate is 1.1-fold (0.03 log units) above the measured one; the measured number falls inside the stated range.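

In this assay, putting hydrogen in place of methoxy on the aromatic carbon gives no change at the digits printed from compound 2 to compound 4 (within the scatter), so on the core of compound 2 this swap leaves the half-life where it was. The same swap therefore behaves alike on both cores shown, with no real gap between the two steps: the same change on two cores in this assay, a 1.1-fold higher number (0.02 log units; within the scatter) from compound 1 to compound 3 and no change at the digits printed (within the scatter) from compound 2 to compound 4, 1.1-fold (0.02 log units) apart, within the scatter of two such steps

This agreement rests on just two cores, and it does not show that the swap would behave the same way on a further core; since neither step moved the number, these pairs also cannot test whether a change that does move the half-life would carry over from one core to another.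

On these data alone, whether a chlorine atom, an amine or a longer alkoxy chain on that aromatic carbon would shift the half-life on either core stays open. As far as these compounds go, it also stays open which part of the difference between the core of compound 2 and the core of compound 1 matters for the half-life.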